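The compounds below may be only part of what the source reports. "The series", "measured", "known", "first", "only" and "open" are said of these compounds alone.

Working notes on a small set of three measured compounds and one still open. In a functional assay on MCF7 cells (Homo sapiens) for antiproliferative activity, read by sulforhodamine B assay, with a stated time of 48 h (a higher number here means a weaker inhibitor, a lower number a stronger inhibitor), compound 1 `CC(=O)Nc1ccc(S(=O)(=O)Oc2ccccc2C(C)C)cc1` gives 16000 nM. Compound 2 `CC(=O)Nc1ccc(S(=O)(=O)Oc2ccccc2I)cc1` carries iodo in place of isopropyl on an aromatic carbon. In this assay compound 2 gives 27000 nM. The step is a 1.7-fold higher number from compound 1 to compound 2 (0.23 log units; within the scatter). Compound 3 `CC(C)c1ccccc1OS(=O)(=O)c1ccc(NC(=O)CCCl)cc1` differs from compound 1 in the core, by chloromethyl in place of hydrogen on a saturated chain carbon bound to a carbonyl carbon. In this assay compound 3 gives 9000 nM. That step is a 1.8-fold lower number from compound 1 to compound 3 (0.25 log units; within the scatter). Compound 3 and compound 1 lie within the scatter of each other, whereas compound 3 and compound 2 lie beyond it.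

Compound 4 `O=C(CCCl)Nc1ccc(S(=O)(=O)Oc2ccccc2I)cc1` is not yet measured. It differs from compound 3 by iodo in place of isopropyl on an aromatic carbon, and the description of the place matches word for word that of the change from compound 1 to compound 2, so the change is the same one on a different core. On the core of compound 3 the step is expected to be a 1.7-fold higher number from compound 3 to compound 4 (0.22 log units; within the scatter), resting on the only earlier occurrence, a 1.7-fold higher number from compound 1 to compound 2 (0.23 log units; within the scatter), which stayed within the scatter. The estimate for compound 4 in this assay is 15000 nM, with a range from 7000 nM to 35000 nM.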

Compound 4, half-maximal inhibitory concentration: 8900 nM
Compound 4: middle estimate off by 1.7-fold (0.23 log units), on the high side; low and high end bracket the measured number.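

In this assay iodo in place of isopropyl gives a 1.0-fold lower number from compound 3 to compound 4 (0.00 log units; within the scatter) and so carries between the two cores with no difference beyond the scatter: the same change on two cores in this assay, a 1.7-fold higher number (0.23 log units; within the scatter) from compound 1 to compound 2 and a 1.0-fold lower number (0.00 log units; within the scatter) from compound 3 to compound 4, 1.7-fold (0.23 log units) apart, within the scatter of two such steps.

The chloromethyl change gives a 3.0-fold lower number from compound 2 to compound 4 (0.48 log units; beyond the scatter) and, although this step alone lies beyond the scatter while its counterpart does not, the two cannot be told apart: the same change on two cores in this assay, a 1.8-fold lower number (0.25 log units; within the scatter) from compound 1 to compound 3 and a 3.0-fold lower number (0.48 log units; beyond the scatter) from compound 2 to compound 4, 1.7-fold (0.23 log units) apart, within the scatter of two such steps.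

Both changes therefore transfer between these cores as far as this assay can resolve, but that rests on a single square of four compounds and does not show that either change would transfer to any other core in the series.

Open, on these data alone, is how other groups would behave on the same aromatic carbon, for instance a methoxy group or a nitrile in place of iodo. Equally open, as far as these compounds go, is whether the chloromethyl gain persists with a longer chain on the amide carbonyl, or with an amine in place of the chlorine.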